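A few compounds are considered here, and "the series" means these few. Any claim that something is new, unique, unknown or untested is made for them only; others in the source may bear on it.

Measured in a functional assay on MT4 cells (Homo sapiens) for cytotoxicity, read by MTT assay; a higher number here means that more compound is tolerated, a lower number that less compound is tolerated:
Compound 1 `Cc1c(O)nc(SCc2ccc(Cl)cc2)nc1Cc1c(Cl)cccc1Cl`: > 59000 nM
Compound 2 `Cc1c(O)nc(SCc2ccccc2)nc1Cc1c(Cl)cccc1Cl`: > 64000 nM
Compound 3 `COc1ccc(CSc2nc(O)c(C)c(Cc3c(F)cccc3F)n2)cc1`: > 64000 nM

All three values are limits and not numbers. Compound 2 sits at the limit of > 64000 nM in this assay, at which 2 of the 3 values shown sit, so its own position is known only as a limit. Compound 4 `Cc1c(O)nc(SCc2ccc(F)cc2)nc1Cc1c(Cl)cccc1Cl` differs from compound 2 by fluoro in place of hydrogen on an aromatic carbon, with fluoro in place of hydrogen on an aromatic carbon. For the measured compounds named here, the one measured step that bears on this, a step that the two limits leave unreadable from compound 1 to compound 2, puts hydrogen in place of chloro on an aromatic carbon and gives no size, so no step beyond the scatter is expected in this assay, in either direction. This amounts to an expected a number no higher from compound 2 to compound 4 (the limit leaves the size open). For compound 4 the estimated value is 64000 nM, with an expected range of 30000 nM to 100000 nM.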

Compound 4, half-maximal cytotoxic concentration: > 61000 nM
Compound 4: no number, only a limit (the forecaster's own chance of this, stated with the estimate: 85%); the middle value is on the limit's open side.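

For the compounds shown here, compound 1, compound 2 and compound 4 each give only a limit in this assay, so no step among them can be read. On these data alone, whether hydrogen, fluoro or chloro at this place changes tolerance remains open.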